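This account rests on a few compounds, and the source may have more. Where it says the series, first, only, none or still open, it means among the compounds named here.

Measured so far in a functional assay on WI-38 VA13 cells (Homo sapiens) for cytotoxicity; a higher number here means that more compound is needed for the effect, a lower number that less compound is needed:
compound 1 `O=C(Nc1ccc2nc(NC(=O)C3CCCCC3)sc2c1)c1c(F)cccc1C(F)(F)F` gives 0.032 ug/mL
compound 2 `CC(=O)Nc1ccc2nc(NC(=O)C3CCCCC3)sc2c1` gives 2.7 ug/mL
compound 3 `NCCC(=O)Nc1nc2ccc(NC(=O)c3c(Cl)cccc3Cl)cc2s1` gives 5.3 ug/mL

Compound 3 holds the highest of the three numbers. Its nearest neighbour is compound 2, whose value lies within the usual scatter of that of compound 3, so no order can be read between the two. The gap to compound 1 is far beyond the scatter: compound 1 needs much less material for the effect than compound 3 does.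

Compound 4 `CCCCCNc1nc2ccc(NC(=O)c3c(Cl)cccc3Cl)cc2s1` has not yet been measured in this assay. It differs from compound 3 in one place: pentyl in place of (2-aminoethyl)carbonyl on a nitrogen on an aromatic ring. Within the data shown here, no pair of measured compounds shows a change of this kind, so the expectation rests on the spread of the series alone. A modest step toward a lower number is expected, the step of a 2.7-fold lower number from compound 3 to compound 4 (0.42 log units; beyond the scatter) likely remaining close to the scatter. Compound 4 is estimated at 2 ug/mL, expected to fall between 0.3 ug/mL and 12 ug/mL.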

Compound 4, half-maximal effective concentration: 0.27 ug/mL
Compound 4: middle estimate off by 7.4-fold (0.87 log units), on the high side; the whole stated range lies above it.
By their numbers in this assay, from the lowest: compound 1; then compound 4; then compounds 2 and 3 (each within the scatter of the next).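

Among these compounds, at the nitrogen on an aromatic ring, pentyl in place of (2-aminoethyl)carbonyl gives a 20-fold lower number from compound 3 to compound 4 (1.29 log units; beyond the scatter) in this assay, the first one-place step. Both groups hold the same count of heavy atoms, so the size of this step does not follow from that count. Nothing measured here gives a reason for the step.

Still open, as far as these compounds go, is whether the carbonyl or the terminal amine goes with the step, which a pentanoyl group or a 5-aminopentyl group would separate. A longer alkyl chain at this nitrogen would show how far the trend runs.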